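Removing Dimethylamino from a Nearly Inactive Compound

The compounds below may be only part of what the source reports. "The series", "measured", "known", "first", "only" and "open" are said of these compounds alone.

Compound 1 `O=C1/C(=C/c2ccc(Cl)cc2)CCC/C1=C\c1ccccc1[N+](=O)[O-]`: 3700 nM
Compound 2 `CN(C)c1ccc(/C=C2\CCC/C(=C\c3ccccc3[N+](=O)[O-])C2=O)cc1`: > 400000 nM

In a functional assay on HSC-2 cells (Homo sapiens) for cytotoxicity, with a stated time of 24 h (a higher number here means that more compound is tolerated, a lower number that less compound is tolerated), compound 2 stands at > 400000 nM, which is a limit of the assay and not a number. Compound 3 `Cc1ccc(/C=C2\CCC/C(=C\c3ccccc3[N+](=O)[O-])C2=O)cc1` has methyl in place of dimethylamino on an aromatic carbon, para to a large group: methyl in place of dimethylamino on an aromatic carbon. For the measured compounds named here, one measured step bears on this change, the large at least 100-fold higher number from compound 1 to compound 2 (2.03 log units; beyond the scatter), where dimethylamino replaced chloro. Compound 3 loses dimethylamino, so a value nearer that of compound 1 at 3700 nM is expected. The expected result is a large downward step, an at least 50-fold lower number from compound 2 to compound 3 (1.69 log units; beyond the scatter). For compound 3 the estimated value is 8000 nM, with an expected range of 2000 nM to 40000 nM.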

Compound 3, half-maximal cytotoxic concentration: 11000 nM
The estimate for compound 3 lay 1.4-fold (0.14 log units) below the measured number, and the stated range covers the measured number.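

In this assay, methyl in place of dimethylamino gives an at least 36-fold lower number from compound 2 to compound 3 (1.56 log units; beyond the scatter), so the large rise seen with dimethylamino does not come simply from losing chloro at this position. Chloro and methyl still differ, though only modestly, with a 3.0-fold higher number from compound 1 to compound 3 (0.47 log units; beyond the scatter). Compound 2 stands at a limit of the assay, not a number, so the first step has no exact size: the limit of > 400000 nM in this assay, at which 1 of the 3 values shown sits.

Open, on these data alone, is whether a plain amino group or a methoxy group here would stay near compound 1 and compound 3 or move towards compound 2.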